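This account rests on a few compounds, and the source may have more. Where it says the series, first, only, none or still open, it means among the compounds named here.

In a functional assay on HepG2 cells (Homo sapiens) for inhibition (on this read-out higher numbers stand for weaker inhibition and lower numbers for stronger inhibition), compound 1 (`Cc1nc2c(s1)C(=O)C=C(Nc1ccc(Br)cc1)C2=O`) gives 2.78 ug/mL and compound 2 (`Cc1nc2c(s1)C(=O)C=C(Nc1ccc(I)cc1)C2=O`) gives 1.95 ug/mL so the two sit within the scatter of each other. Compound 3 (`Cc1nc2c(s1)C(=O)C=C(Nc1ccc(O)cc1)C2=O`) differs from compound 2 as follows: hydroxy in place of iodo on an aromatic carbon with hydroxy in place of iodo on an aromatic carbon. Among the compounds with values here, the one measured step (a 1.4-fold lower number from compound 1 to compound 2 (0.15 log units; within the scatter)) puts iodo in place of bromo, and no measured step involves hydroxy, so it offers only weak guidance. A modest step toward a higher number in this assay is expected, with the direction uncertain. For compound 3 the estimated value is 3.5 ug/mL with an expected range from 1.2 ug/mL to 10 ug/mL in this series. The expected change is a 1.8-fold higher number from compound 2 to compound 3 (0.25 log units; within the scatter) on this estimate.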

Compound 3, half-maximal inhibitory concentration: 1.36 ug/mL
For compound 3 the middle estimate is 2.6-fold (0.41 log units) above the measured one; low and high end bracket the measured number.
By their numbers in this assay, from the lowest: compounds 3, 2 and 1 (each within the scatter of the next, the first and the last beyond it).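

On the aromatic carbon para to a large group, hydroxy in place of iodo gives a 1.4-fold lower number from compound 2 to compound 3 (0.16 log units; within the scatter) in this assay, so a hydrogen-bond donor and acceptor at this place keeps the number level with the iodo compound. Hydroxy in place of bromo gives a 2.0-fold lower number from compound 1 to compound 3 (0.31 log units; beyond the scatter), the only step so far beyond the scatter, and it is modest. Nothing measured bears on the reason for these numbers.

Open, going by these compounds, is whether an amine or a methoxy group at this place would hold the number in the same range. Also open, on these data alone, is whether a carboxylic acid would do so.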